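Sulfonyl Chain Swap on a Flat Antiproliferative Series

The compounds below may be only part of what the source reports. "The series", "measured", "known", "first", "only" and "open" are said of these compounds alone.

Values in a functional assay on CWR22R cells (Homo sapiens) for antiproliferative activity, read by MTT assay, with a stated time of 3 days; on this read-out lower numbers stand for stronger inhibition and higher numbers for weaker inhibition:
- compound 1 `COc1cc(O)c2c(=O)cc(-c3ccc(NS(C)(=O)=O)cc3)oc2c1OC(C)C`: 3800 nM
- compound 2 `CCS(=O)(=O)Nc1ccc(-c2cc(=O)c3c(O)cc(OC)c(OC(C)C)c3o2)cc1`: 2900 nM
- compound 3 `CCCS(=O)(=O)Nc1ccc(-c2cc(=O)c3c(O)cc(OC)c(OC(C)C)c3o2)cc1`: 2900 nM

Compound 3 gives 2900 nM, the same number as compound 2 at the digits shown and within the scatter of compound 1. The unmeasured compound 4 `COc1cc(O)c2c(=O)cc(-c3ccc(NS(=O)(=O)C4CC4)cc3)oc2c1OC(C)C` differs from compound 3 by cyclopropyl in place of propyl on a sulfonyl sulfur. The measured steps that bear on this swap all alter the same chain on the sulfonyl sulfur. They are a 1.3-fold lower number from compound 1 to compound 2 (0.12 log units; within the scatter) and a 1.3-fold lower number from compound 1 to compound 3 (0.12 log units; within the scatter), along with no change at the digits printed from compound 2 to compound 3 (within the scatter). None of them brings in a ring, so the data do not test that feature directly. Resting on these three small steps, no change beyond the scatter is expected in this assay. The expected step is a 1.0-fold higher number from compound 3 to compound 4 (0.01 log units; within the scatter). Compound 4 is estimated at 3000 nM, with an expected range from 1500 nM to 6000 nM.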

Compound 4, half-maximal inhibitory concentration: 19700 nM
Compound 4: the middle estimate sits 6.6-fold (0.82 log units) below what was measured; measured number above the stated range.
By their numbers in this assay, from the lowest: compounds 2, 3 and 1 (each within the scatter of the next); then compound 4.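

On the sulfonyl sulfur, the open chains methyl, ethyl and propyl had given numbers within the scatter of one another in this assay, but the cyclopropyl ring breaks that flat picture, against propyl (a 6.8-fold higher number from compound 3 to compound 4 (0.83 log units; beyond the scatter)), against ethyl (a 6.8-fold higher number from compound 2 to compound 4 (0.83 log units; beyond the scatter)) and against methyl (a 5.2-fold higher number from compound 1 to compound 4 (0.71 log units; beyond the scatter)). The position is therefore not indifferent to what sits on the sulfur, and since cyclopropyl and propyl match in heavy atoms, that count alone does not set the number here. Nothing measured here gives a reason for this step.

The compounds shown leave open whether the loss belongs to the ring as such or to branching at the carbon on the sulfur. An isopropyl or a cyclobutyl on the sulfonyl sulfur would speak to that, and a butyl chain would show how far the flat run of open chains extends.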